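Working notes: the step from compound 2 to compound 3

The source may report more compounds than this note shows. Statements on the series, on what has been measured and on what is new or still open speak of the compounds shown alone.

- compound 1 `O=C(NC[C@@H]1[C@H]2CN(C(=O)/C=C/c3cc(Cl)cc(Cl)c3)C[C@@H]12)c1ccc2[nH]c(=O)oc2c1`: < 1 ug/mL
- compound 2 `O=C(NC[C@@H]1[C@H]2CN(C(=O)NCc3cc(Cl)cc(Cl)c3)C[C@@H]12)c1ccc2[nH]c(=O)oc2c1`: < 1 ug/mL

In a physicochemical assay for solubility, with a stated time of 24 h, at pH 6.8 (a lower number here means a less soluble compound, a higher number a more soluble compound), compound 2 stands at < 1 ug/mL, which is a limit and not a number. Compound 1 gives < 1 ug/mL, also a limit. Both measured compounds therefore share one reading: the limit of < 1 ug/mL in this assay, at which 2 of the 2 values shown sit.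

Compound 3 `CC(OC(=O)N1C[C@@H]2[C@@H](CNC(=O)c3ccc4[nH]c(=O)oc4c3)[C@@H]2C1)c1cc(Cl)cc(Cl)c1` follows from compound 2 as a group of 11 heavy atoms (8 carbon, 1 oxygen, 2 chlorine; one six-membered aromatic ring of carbon only) in place of a group of 10 heavy atoms (7 carbon, 1 nitrogen, 2 chlorine; one six-membered aromatic ring of carbon only), on a carbonyl carbon. The group that leaves is (3,5-dichlorobenzyl)amino, and the other neighbour of the carbonyl carbon is an amide-type nitrogen in a ring.

For the measured compounds named here, the only measured step, also on a carbonyl carbon, is a step that the two limits leave unreadable from compound 1 to compound 2. It offers no size or direction to carry over, so no step beyond the scatter is expected in this assay. The estimated step is a step that the limit leaves unreadable from compound 2 to compound 3. For compound 3 the expected value is 0.8 ug/mL, with an estimated range of 0.3 ug/mL to 3 ug/mL.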

Compound 3, solubility: < 1 ug/mL
Compound 3 was reported as a limit (the forecaster's own chance of this, stated with the estimate: 80%); the middle value does not contradict the limit.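

In this assay compound 3 gives < 1 ug/mL, which is a limit and not a number. No step can be read among compound 1, compound 2 and compound 3: the limit of < 1 ug/mL in this assay, at which 3 of the 3 values shown sit. The compounds shown leave open how the solubility of these three compares, and whether any change on the carbonyl carbon moves it.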